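This account rests on a few compounds, and the source may have more. Where it says the series, first, only, none or still open, it means among the compounds named here.

Of the compounds shown here, three of a shared core have so far been tested in an ADME assay on Huh7.5.1 cells (Homo sapiens) for cytotoxicity, read by ATP content, with a stated time of 48 h; a higher number here means that more compound is tolerated, a lower number that less compound is tolerated. Compound 1 `Cc1ccccc1-c1nc(CN2CCC(C(=O)NCCCN3CCC(C)(C)CC3)CC2)c(C)o1` gives 10200 nM, compound 2 `Cc1oc(-c2ccc(F)cc2)nc1CN1CCC(C(=O)NCCCN2C[C@H](C)C[C@H](C)C2)CC1` gives 12800 nM, and compound 3 `CCCN(CCC)CCNC(=O)C1CCN(Cc2nc(-c3ccccc3C)oc2C)CC1` gives 30500 nM. Compound 2 thus stands second highest of the three; its nearest neighbour is compound 1, with a difference within the usual scatter, and its furthest is compound 3, which lies beyond the scatter. Among the measured compounds shown here, the one single-point step measured so far, a 3.0-fold higher number from compound 1 to compound 3 (0.48 log units; beyond the scatter), changes the amine end of the chain and is modest.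

Compound 4 `COc1cccc(F)c1-c1nc(CN2CCC(C(=O)NCCCN3C[C@H](C)C[C@H](C)C3)CC2)c(C)o1` is compound 2 with a different change: 2-fluoro-6-methoxyphenyl in place of 4-fluorophenyl on an aromatic carbon. For the measured compounds named here, no measured step touches this part of the molecule, so the step from compound 1 to compound 3 bears on it only by showing that this series moves within a narrow band in this assay. Compounds 1 and 2, which carry different groups at the same aromatic carbon among other differences, give values within the scatter of each other.

The expectation for compound 4 is therefore a step of a 1.2-fold lower number from compound 2 to compound 4 (0.07 log units; within the scatter), no larger than the scatter. Compound 4 is estimated at 11000 nM, within a range of 5000 nM to 25000 nM.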

Compound 4, half-maximal cytotoxic concentration: 37000 nM
Estimate against measurement, compound 4: 3.4-fold (0.53 log units) below; the whole stated range lies below it.
By their numbers in this assay, from the lowest: compounds 1 and 2 (each within the scatter of the next); then compounds 3 and 4 (each within the scatter of the next).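

Among the compounds shown here, this is the first step at this position, the aromatic carbon of the five-membered aromatic ring, and it shows that the aryl group here can shift the result in this assay: 2-fluoro-6-methoxyphenyl in place of 4-fluorophenyl gives a 2.9-fold higher number from compound 2 to compound 4 (0.46 log units; beyond the scatter) and thus more compound tolerated. The step is modest, as is a 3.0-fold higher number from compound 1 to compound 3 (0.48 log units; beyond the scatter) at the amine end of the chain, so a change at either end of the molecule can carry a compound beyond the scatter in this assay. The entering group has two more heavy atoms and one hydrogen-bond acceptor, but no measurement here gives a reason for the step.

This single swap adds the methoxy group and changes the place of the fluorine together, so it leaves open which of the two accounts for the step. A phenyl ring bearing methoxy alone, or a plain phenyl, at this carbon would help to separate them, and pairing 2-fluoro-6-methoxyphenyl with the dipropylamino end would test whether the two steps add up.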